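The compounds below may be only part of what the source reports. "The series", "measured", "known", "first", "only" and "open" are said of these compounds alone.

Working notes on the series around the shared core of compound 3 `O=c1c2ccccc2[se]n1-c1nc(SCc2ccccc2)n[nH]1`. In a functional assay on SMMC-7721 cells (Homo sapiens) for antiproliferative activity, read by CCK-8 assay, with a stated time of 48 h (on this read-out higher numbers stand for weaker inhibition and lower numbers for stronger inhibition), compound 3 gives 32000 nM, the lowest of the two numbers shown. Compound 2 `O=c1c2ccccc2[se]n1-c1nc(SCc2ccc(Cl)cc2)n[nH]1` gives 33900 nM in this assay; the step of a 1.1-fold lower number from compound 2 to compound 3 (0.03 log units; within the scatter) lies within the scatter, so the two do not separate. Compound 1 `Cc1ccc(CSc2n[nH]c(-n3[se]c4ccccc4c3=O)n2)cc1` returns in this assay only a limit of the assay, > 50000 nM, and no number. The steps of an at least 1.4-fold lower number from compound 1 to compound 2 (0.16 log units; that floor lies within the scatter) and an at least 1.5-fold lower number from compound 1 to compound 3 (0.19 log units; that floor lies within the scatter) have floors that lie within the scatter, as one value sits at the limit of > 50000 nM in this assay, at which 1 of the 3 values shown sits, so the three substituents on the six-membered aromatic ring of carbon only have not told the compounds apart. Compound 4 `O=c1c2ccccc2[se]n1-c1nc(SCc2ccc([N+](=O)[O-])cc2)n[nH]1` differs from compound 3 by nitro in place of hydrogen on an aromatic carbon. This change sits at the same site as the measured steps, each of which stayed within the scatter, so no step beyond the scatter is expected in this assay, in either direction. The step to compound 4 is expected to be a 1.1-fold lower number from compound 3 to compound 4 (0.03 log units; within the scatter). Compound 4 is expected to give 30000 nM in this assay, in the range 12000 nM to 80000 nM.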

Compound 4, half-maximal inhibitory concentration: 8910 nM
Compound 4: the middle estimate sits 3.4-fold (0.53 log units) above what was measured, and the stated range ends above it.
By their numbers in this assay, from the lowest: compound 4; then compounds 3 and 2 (each within the scatter of the next). At a limit, above all of these: compound 1.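

In this assay, among these compounds, this position, on the six-membered aromatic ring of carbon only and para to a large group, can move the read-out: nitro is the first substituent there to separate from the others, with a 3.6-fold lower number from compound 3 to compound 4 (0.56 log units; beyond the scatter) and a 3.8-fold lower number from compound 2 to compound 4 (0.58 log units; beyond the scatter). Hydrogen and chloro, in compound 3 and compound 2, did not separate from each other, so the series responds here to nitro and not to every change at this site. Against the methyl analogue, the change reads an at least 5.6-fold lower number from compound 1 to compound 4 (0.74 log units; beyond the scatter), and this size is only a floor, as one value is a limit of the assay: the limit of > 50000 nM in this assay, at which 1 of the 4 values shown sits.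

With nitro the only substituent that separates, no trend across substituents can be drawn from these four compounds. From the compounds shown here alone, whether a nitrile, a carboxylic acid or an amine at this position would give a step of similar size remains open.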